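A Chloro Substituent Enters a Saturated Ring

This account rests on a few compounds, and the source may have more. Where it says the series, first, only, none or still open, it means among the compounds named here.

Of the compounds shown here, two have been measured so far in a functional assay (Platelet, plasma) for inhibition, with Homo sapiens as the target; a lower number here means a stronger inhibitor, a higher number a weaker inhibitor. Compound 1 `Cc1ccc(CS(=O)(=O)NC(=O)C2CCN(c3nc4c(cc3C#N)C(=O)OC4)CC2)cc1` gives 4280 nM in this assay. Compound 2 `N#Cc1cc2c(nc1N1CCC(C(=O)NS(=O)(=O)Cc3ccccc3)CC1)CCCC2=O` gives 117000 nM in this assay, the highest of the two numbers, and its gap to compound 1 lies beyond the scatter. Among the measured compounds shown here, these two compounds differ in more than one place, so no single step between them is counted, and their two values alone describe the pair.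

Compound 3 `N#Cc1cc2c(nc1N1CCC(C(=O)NS(=O)(=O)Cc3ccccc3)CC1)CCC(Cl)C2=O` has not yet been measured in this assay. It differs from compound 2 in one place: chloro in place of hydrogen on a saturated ring carbon. For the measured compounds named here, none of the measured compounds shows how such a change moves the number in this assay, so any expectation rests on the change alone. The change is expected to produce only a small step, a 1.5-fold lower number from compound 2 to compound 3 (0.17 log units; within the scatter), one that may not reach beyond the scatter in either direction. Compound 3 is therefore estimated to give 80000 nM in this assay, with a range from 25000 nM to 250000 nM.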

Compound 3, half-maximal inhibitory concentration: > 300000 nM
Compound 3 was reported as a limit (the forecaster's own chance of this, stated with the estimate: 15%); middle value at least 3.7-fold (0.57 log units) from the limit.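

Chloro in place of hydrogen on a saturated ring carbon is the first change in one place among these compounds, and in this assay it gives an at least 2.5-fold higher number from compound 2 to compound 3 (0.40 log units; beyond the scatter). This shows that the saturated ring carbon, in a six-membered non-aromatic ring of carbon only, is not indifferent to substitution: a single chlorine atom here goes with a weaker inhibitor, even though compound 2 already has the highest measured number of the earlier pair. Compound 3 is known only as a limit, so the step gives a floor for the change and not its full size: the limit of > 300000 nM in this assay, at which 1 of the 3 values shown sits.

The compounds shown leave open whether the higher number belongs to chloro in particular or would also follow from another group on this carbon, such as a hydroxyl group or an amine. They also leave open whether chloro would move the number in the same direction on the core of compound 1, which differs from compound 2 in more than one place and so offers no single-step comparison.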